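Replacing the amino group of compound 2 with methylpiperazine

This account rests on a few compounds, and the source may have more. Where it says the series, first, only, none or still open, it means among the compounds named here.

Compound 2 `NCc1nc2ccccc2c(-c2ccccc2)c1C(=O)NCc1cc(C(F)(F)F)cc(C(F)(F)F)c1` gives 0.0017 nM in an in vitro assay on UC11MG cells for binding affinity to Substance-P receptor (Homo sapiens), read by radioligand binding (a lower number here means a stronger inhibitor, a higher number a weaker inhibitor), the lowest of the three numbers measured. Compound 3 `CN(Cc1cc(C(F)(F)F)cc(C(F)(F)F)c1)C(=O)c1c(CN)nc2ccccc2c1-c1ccccc1` gives 9 nM in this assay, and compound 1 `CN(Cc1cc(C(F)(F)F)cc(C(F)(F)F)c1)C(=O)c1c(CO)nc2ccccc2c1-c1ccccc1` gives 16 nM. The gap a 5300-fold higher number from compound 2 to compound 3 (3.72 log units; beyond the scatter) shows how much the amide hydrogen matters in this series. By contrast, the step of a 1.8-fold lower number from compound 1 to compound 3 (0.25 log units; within the scatter) shows that swapping the group on the saturated chain carbon bound to an aromatic carbon changes little.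

Compound 4 `CN1CCN(Cc2nc3ccccc3c(-c3ccccc3)c2C(=O)NCc2cc(C(F)(F)F)cc(C(F)(F)F)c2)CC1` keeps the amide hydrogen of compound 2 and differs only in that (4-methylpiperazin-1-yl in place of amino on a saturated chain carbon bound to an aromatic carbon). Going by the values given here, the one measured step that touches this position, from compound 1 to compound 3, stayed within the scatter, so the new group is expected to leave the number close to that of compound 2, perhaps with a modest rise; nothing in the data points to a number lower than the value of compound 2, which is 0.0017 nM. Compound 4 is therefore estimated at 0.005 nM, within 0.001 nM to 0.03 nM, an expected step of a 2.9-fold higher number from compound 2 to compound 4 (0.47 log units; beyond the scatter).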

Compound 4, half-maximal inhibitory concentration: > 1000 nM
Compound 4: only a limit was reported; the forecaster's own chance of this, stated with the estimate: 5%; at least 200000-fold (5.30 log units) between middle value and limit.
By their numbers in this assay, from the lowest: compound 2; then compounds 3 and 1 (each within the scatter of the next). At a limit, above all of these: compound 4.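

Going by these compounds alone, this position, on a saturated chain carbon bound to an aromatic carbon, tolerates far less than the earlier compounds suggested: in this assay, 4-methylpiperazin-1-yl in place of amino gives an at least 580000-fold higher number from compound 2 to compound 4 (5.76 log units; beyond the scatter), whereas hydroxy to amino gives only a 1.8-fold lower number from compound 1 to compound 3 (0.25 log units; within the scatter). From the compounds shown here alone, compound 4 is reported only as a limit, so the full size of its step stays unknown: the limit of > 1000 nM in this assay, at which 1 of the 4 values shown sits. The single nitrogen of the amino group gives way here to a six-membered non-aromatic ring with a methyl group on it, and this one change cannot show which of those features matters.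

Going by these compounds, it remains open whether a smaller amine, such as methylamino or dimethylamino, would stay close to compound 2 at 0.0017 nM. A morpholine ring or an unsubstituted piperazine ring at this position is also untested among the compounds shown here.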